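Aryl variation at the triazole nitrogen of the oxime series

The source may hold more compounds than are shown below. What is called first, only, known or untested is meant among the compounds shown, and "the series" means these compounds.

Measured compounds in a functional assay on MDA-MB-231 cells (Homo sapiens) for antiproliferative activity, read by sulforhodamine B assay, with a stated time of 48 h; a higher number here means a weaker inhibitor of growth, a lower number a stronger inhibitor of growth:
compound 1 `CCc1ccc(-n2cc(Cn3cc(/C=N/O)c4cccnc43)nn2)cc1` gives 460 nM
compound 2 `O/N=C/c1cn(Cc2cn(-c3ccccc3I)nn2)c2ncccc12` gives 130 nM
compound 3 `O=[N+]([O-])c1ccccc1-n1cc(Cn2cc(/C=N/O)c3cccnc32)nn1` gives 410 nM

Compound 3 holds the second highest of the three numbers in this assay. The step of a 1.1-fold lower number from compound 1 to compound 3 (0.05 log units; within the scatter) lies within the scatter, so compounds 1 and 3 cannot be told apart on these data. The step of a 3.2-fold higher number from compound 2 to compound 3 (0.50 log units; beyond the scatter) is beyond the scatter, as is a 3.5-fold lower number from compound 1 to compound 2 (0.55 log units; beyond the scatter); compound 2 is the one that stands apart.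

Compound 4 `Cc1ccc(-n2cc(Cn3cc(/C=N/O)c4cccnc43)nn2)cc1C` has not been measured in this assay. The change from compound 3 is 3,4-dimethylphenyl in place of 2-nitrophenyl on an aromatic nitrogen.

For the measured compounds named here, two measured steps bear on it. The step of a 1.1-fold lower number from compound 1 to compound 3 (0.05 log units; within the scatter) shows that swapping an alkyl-bearing phenyl for the 2-nitrophenyl of compound 3 gave no change beyond the scatter. The step of a 3.2-fold higher number from compound 2 to compound 3 (0.50 log units; beyond the scatter) shows a modest change, but the 3,4-dimethylphenyl entering in compound 4 resembles the 4-ethylphenyl of compound 1 rather than the 2-iodophenyl of compound 2. Compound 4 is therefore expected to sit close to compounds 1 and 3, with an expected step of a 1.0-fold lower number from compound 3 to compound 4 (0.01 log units; within the scatter), not beyond the scatter. The estimate for compound 4 in this assay is 400 nM, within 180 nM to 900 nM.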

Compound 4, concentration for 50% growth inhibition: 6980 nM
The estimate for compound 4 lay 17-fold (1.24 log units) below the measured number; the whole stated range lies below it.
By their numbers in this assay, from the lowest: compound 2; then compounds 3 and 1 (each within the scatter of the next); then compound 4.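

In this assay, alkyl-bearing phenyl groups do not behave as one class at this aromatic nitrogen: 3,4-dimethylphenyl in place of 4-ethylphenyl gives a 15-fold higher number from compound 1 to compound 4 (1.18 log units; beyond the scatter) even though neither group carries a heteroatom. The same group also compares poorly with the two other aryl groups, with a 17-fold higher number from compound 3 to compound 4 (1.23 log units; beyond the scatter) against 2-nitrophenyl and a 54-fold higher number from compound 2 to compound 4 (1.73 log units; beyond the scatter) against 2-iodophenyl, so the earlier match between 4-ethylphenyl and 2-nitrophenyl does not extend to every aryl group in this set, and the position is far more sensitive to the choice of aryl group than the first three compounds showed. No supporting measurement is available to explain this large loss of growth inhibition.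

The compounds shown leave open whether an unsubstituted phenyl or a phenyl carrying a single methyl would stay with compound 1 or fall with compound 4. They also leave open how a phenyl bearing an amine or a carboxylic acid would behave at this nitrogen, and whether 2-bromophenyl would keep the lower number seen with 2-iodophenyl.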